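Methoxycarbonyl on the Anilide Ring: Solubility of Two Cores

This account rests on a few compounds, and the source may have more. Where it says the series, first, only, none or still open, it means among the compounds named here.

The measured compounds and their values:

Compound 1, `O=C(Nc1ccccc1)c1cc2cc([N+](=O)[O-])ccc2s1`: 10 ug/mL
Compound 2, `COC(=O)c1ccc(NC(=O)c2cc3cc([N+](=O)[O-])ccc3o2)cc1`: 20 ug/mL
Compound 3, `O=C(Nc1ccccc1)c1cc2cc([N+](=O)[O-])ccc2o1`: 25 ug/mL

All three were tested in a physicochemical assay for solubility; on this read-out lower numbers stand for lower solubility and higher numbers for higher solubility. Compound 3 and compound 2 share a core and differ in one place, the change being (methoxycarbonyl in place of hydrogen on an aromatic carbon). That change produced a 1.3-fold lower number from compound 3 to compound 2 (0.10 log units; within the scatter). Compound 1 carries a different core; the difference between the two cores is not broken down here. Compound 1 gives the lowest of the three numbers, and its gap to compound 2 lies within the scatter, while its gap to compound 3 lies beyond it.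

Compound 4, `COC(=O)c1cccc(NC(=O)c2cc3cc([N+](=O)[O-])ccc3s2)c1`, has not yet been measured in this assay. It stands to compound 1 as compound 2 stands to compound 3: the change is methoxycarbonyl in place of hydrogen on an aromatic carbon. The two places are not identical, since the group in compound 2 sits para to a large group and in compound 4 meta to a large group, so this is the same kind of change rather than the same change.

The expectation for compound 4 rests on the earlier pair: since the same kind of change gave a 1.3-fold lower number from compound 3 to compound 2 (0.10 log units; within the scatter), the step from compound 1 is estimated at about a 1.3-fold lower number from compound 1 to compound 4 (0.10 log units; within the scatter). Compound 4 is therefore expected to give 8 ug/mL, with an estimated range from 3 ug/mL to 20 ug/mL.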

Compound 4, solubility: 25 ug/mL
Estimate against measurement, compound 4: 3.1-fold (0.49 log units) below; the measured number lies above the stated range.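

Methoxycarbonyl in place of hydrogen on an aromatic carbon, meta to a large group, gave a 2.5-fold higher number from compound 1 to compound 4 (0.40 log units; beyond the scatter) in this assay, whereas the same kind of change on the other core gave a 1.3-fold lower number from compound 3 to compound 2 (0.10 log units; within the scatter) and thus no step beyond the scatter. Within the data shown here, this shows that, across these two pairs, the step seen on one core did not carry over to the other, so a result for this kind of change on one core gave no safe guide to its size or direction on the other; it does not show that the core alone sets the outcome, since the two pairs differ in their core and also in where the methoxycarbonyl group stands, and each core offers only a single pair. Nothing among the data shown bears on why the two steps part ways.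

The compounds shown leave open how methoxycarbonyl would behave in both places on one and the same core, which would separate the place from the core. They also leave open whether a carboxylic acid or an amine in that same place would follow compound 4 on either core.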